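The source may hold more compounds than are shown below. What is called first, only, known or untested is meant among the compounds shown, and "the series" means these compounds.

In a functional assay on BJAB cells (Homo sapiens) for antiproliferative activity, with a stated time of 4 days (a lower number here means that less compound is needed, a higher number that more compound is needed for the effect), compound 3 `Cc1ccc(-c2c(C)nn(-c3nc(-c4ccc(Cl)c(Cl)c4)c(SC(C)C)s3)c2C(=O)O)cc1` gives 3800 nM, at the low end of the three numbers. Compound 2 `Cc1ccccc1-c1c(C)nn(-c2nc(-c3ccc(Cl)c(Cl)c3)c(SC(C)C)s2)c1C(=O)O` gives 5500 nM, and the step of a 1.4-fold lower number from compound 2 to compound 3 (0.16 log units; within the scatter) lies within the scatter. Compound 1 `COc1cncc(-c2c(C)nn(-c3nc(-c4ccc(Cl)c(Cl)c4)c(SC(C)C)s3)c2C(=O)O)c1` gives 21000 nM, and both a 5.5-fold lower number from compound 1 to compound 3 (0.74 log units; beyond the scatter) and a 3.8-fold lower number from compound 1 to compound 2 (0.58 log units; beyond the scatter) lie beyond the scatter. Compound 4 `COc1cc(C#N)cc(-c2c(C)nn(-c3nc(-c4ccc(Cl)c(Cl)c4)c(SC(C)C)s3)c2C(=O)O)c1` differs from compound 3 by 3-cyano-5-methoxyphenyl in place of 4-methylphenyl on an aromatic carbon. The step of a 5.5-fold lower number from compound 1 to compound 3 (0.74 log units; beyond the scatter) bears on this change: there a 5-methoxypyridin-3-yl gave way to 4-methylphenyl, and compound 4 brings a methoxy group back, now on a 3-cyano-5-methoxyphenyl. A higher number in this assay, of modest size, is therefore expected. Compound 4 is estimated at 10000 nM, in a range from 4000 nM to 25000 nM, an expected step of a 2.6-fold higher number from compound 3 to compound 4 (0.42 log units; beyond the scatter).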

Compound 4, half-maximal effective concentration: 5200 nM
Beside the measured number, compound 4's estimate is 1.9-fold (0.28 log units) above it; measured number inside the range.
By their numbers in this assay, from the lowest: compounds 3, 4 and 2 (each within the scatter of the next); then compound 1.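

Adding a nitrile and a methoxy to the phenyl ring leaves this position's number unchanged within the scatter, with a 1.4-fold higher number from compound 3 to compound 4 (0.14 log units; within the scatter) and a 1.1-fold lower number from compound 2 to compound 4 (0.02 log units; within the scatter). The methoxy therefore does not by itself bring back the high number of compound 1, as a 4.0-fold lower number from compound 1 to compound 4 (0.61 log units; beyond the scatter) shows. Across these four compounds, the three phenyl groups stay within the scatter of one another, and only the 5-methoxypyridin-3-yl of compound 1 goes against that pattern.

On these data alone, the separate contributions of the nitrile and the methoxy remain open, as does the effect of an amine or a carboxylic acid on this ring. Nothing available here explains these steps.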